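Moving One Methoxy Group on a Dimethoxyphenyl Ring

The source may hold more compounds than are shown below. What is called first, only, known or untested is meant among the compounds shown, and "the series" means these compounds.

In a functional assay on HL-60 cells (Homo sapiens) for antiproliferative activity, with a stated time of 72 h (on this read-out lower numbers stand for stronger inhibition and higher numbers for weaker inhibition), compound 1 `OC[C@H]1O[C@@H](n2cnc3c(NCc4ccccc4Br)ncnc32)[C@H](O)[C@@H]1O` gives 6600 nM. Compound 2 `COc1cccc(CNc2ncnc3c2ncn3[C@@H]2O[C@H](CO)[C@@H](O)[C@H]2O)c1OC` gives > 166000 nM, which is a limit of the assay and not a number. Going by the values given here, the only measured step is an at least 25-fold higher number from compound 1 to compound 2 (1.40 log units; beyond the scatter), and it replaces the 2-bromophenyl group with 2,3-dimethoxyphenyl. Compound 3 `COc1ccc(CNc2ncnc3c2ncn3[C@@H]2O[C@H](CO)[C@@H](O)[C@H]2O)c(OC)c1` has the same atoms as compound 2, joined differently: 2,4-dimethoxyphenyl in place of 2,3-dimethoxyphenyl on a saturated chain carbon bound to a nitrogen on an aromatic ring. This is a smaller change than the measured one, since both methoxy groups stay, so that step bears on it only loosely. Among the compounds with values here, no measured step shows what moving a methoxy group does. Activity is therefore expected to stay weak, with no change beyond the scatter and quite possibly another limit. The expected step is an at least 1.1-fold lower number from compound 2 to compound 3 (0.04 log units; that floor lies within the scatter). Compound 3 is estimated at 150000 nM, with an expected range from 30000 nM to 400000 nM.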

Compound 3, half-maximal inhibitory concentration: 39000 nM
Compound 3: middle estimate off by 3.8-fold (0.59 log units), on the high side; the measured number falls inside the stated range.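

In this assay, moving one methoxy group, from 2,3-dimethoxyphenyl to 2,4-dimethoxyphenyl, gives an at least 4.2-fold lower number from compound 2 to compound 3 (0.62 log units; beyond the scatter), so this position responds to where a methoxy group sits and not only to which group is present. The move does not recover everything, since replacing 2-bromophenyl with 2,4-dimethoxyphenyl still gives a 5.9-fold higher number from compound 1 to compound 3 (0.77 log units; beyond the scatter), and compound 1 remains the most active of the three. Compound 2 has only a limit and not a number, so the full size of the gain from moving the methoxy group stays unknown: the limit of > 166000 nM in this assay, at which 1 of the 3 values shown sits.

Going by these compounds, it remains open whether a single methoxy group, or an amine or a carboxylic acid on the phenyl ring, would match or beat compound 1. The compounds shown also cannot tell why the placement of the methoxy group matters.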